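The source may hold more compounds than are shown below. What is called first, only, known or untested is meant among the compounds shown, and "the series" means these compounds.

The compounds measured so far:

compound 1, `Cc1cc(OCc2c(-c3c(Cl)cccc3Cl)noc2C(C)C)ncc1[N+](=O)[O-]`, 58%
compound 2, `CC(C)c1onc(-c2c(Cl)cccc2Cl)c1COc1ccc(N(C)Cc2cccc(C(=O)O)c2)c(C(F)(F)F)n1`, 89%
compound 3, `CN(Cc1cccc(C(=O)O)c1)c1ccc(OCc2c(-c3c(Cl)cccc3Cl)noc2C2CC2)nc1C(F)(F)F`, 79%

All three were tested in a functional assay on HEK293 cells for agonist activity at Bile acid receptor (Homo sapiens); on this read-out lower numbers stand for smaller maximal responses and higher numbers for larger maximal responses. Compound 3 and compound 2 give numbers that lie within the scatter of each other, so nothing separates them; compound 1 lies beyond the scatter below compound 3. Within the data shown here, the only measured step, a number 10 percentage points lower from compound 2 to compound 3 (within the scatter), concerns a different change from the one now at hand.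

Compound 4, `O=C(O)c1cccc(OCc2ccc(OCc3c(-c4c(Cl)cccc4Cl)noc3C3CC3)nc2C(F)(F)F)c1`, differs from compound 3 in one place: (3-carboxyphenoxy)methyl in place of (3-carboxybenzyl)(methyl)amino on an aromatic carbon. Among the measured compounds shown here, no measured pair shows what swapping this part of the molecule does, so the step from compound 2 to compound 3 can only indicate that a small change at the far end of the shared core left the response within the scatter. The expectation is therefore a step of no clear size, a number 4 percentage points lower from compound 3 to compound 4 (within the scatter), with the range widened for the lack of a direct precedent. Compound 4 is estimated to give 75%, between 50% and 95%.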

Compound 4, largest response reached (reported as efficacy), in percent of the reference or control that the assay uses: 62%
Compound 4: middle estimate off by 13 percentage points, on the high side; measured number inside the range.
By their numbers in this assay, from the lowest: compounds 1 and 4 (each within the scatter of the next); then compounds 3 and 2 (each within the scatter of the next).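

Among these compounds, this is the first measured sign that the response in this assay depends on how the carboxyphenyl end is attached at this position, on an aromatic carbon ortho to a trifluoromethyl group. Placing (3-carboxyphenoxy)methyl there in place of (3-carboxybenzyl)(methyl)amino gives a number 17 percentage points lower from compound 3 to compound 4 (beyond the scatter), although both groups hold a carboxylic acid on a carbon-only aromatic ring and have the same counts of hydrogen-bond donors and acceptors. Nothing measured here explains the drop.

The change removes the nitrogen with its methyl and also rearranges the chain, so the compounds shown cannot separate these two parts. A (3-carboxybenzyl)oxy group or a (3-carboxybenzyl)amino group at the same position would help tell them apart.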